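Pyrazolone series at GPR39: aryl ether to pyrazolyl ether

This account rests on a few compounds, and the source may have more. Where it says the series, first, only, none or still open, it means among the compounds named here.

Two compounds have numbers in a functional assay on HEK293 cells for agonist activity at G-protein coupled receptor 39 (Homo sapiens), read by scintillation proximity assay and inositol phosphate accumulation, with a stated time of 75 min, in the presence of a further agent that is not named here; a higher number here means that more compound is needed for the effect, a lower number that less compound is needed. Compound 1 `C/C(=N\NC(=O)c1cc2ccccc2cc1O)c1ccc(N)cc1` gives 1100 nM. Compound 2 `Cc1nn(-c2ncnc3nc[nH]c23)c2c1C(OCc1ccc(C(C)C)cc1)CC(=O)N2` gives 5 nM, the lowest of the two, and its gap to compound 1 lies beyond the scatter. Compound 3 `Cc1nn(-c2ncnc3nc[nH]c23)c2c1C(OCCn1cccn1)CC(=O)N2` has not been measured; it differs from compound 2 by (1H-pyrazol-1-yl)methyl in place of 4-isopropylphenyl on a saturated chain carbon bound to an oxygen on a saturated carbon. For the measured compounds named here, no measured pair shows this change, so the expectation rests on compound 2 alone. A step toward a higher number is expected in this assay, of moderate size, a 12-fold higher number from compound 2 to compound 3 (1.08 log units; beyond the scatter). Compound 3 is estimated at 60 nM, within 10 nM to 400 nM.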

Compound 3, half-maximal effective concentration: 16 nM
Compound 3: middle estimate off by 3.8-fold (0.57 log units), on the high side, within the range that was stated.
By their numbers in this assay, from the lowest: compound 2; then compound 3; then compound 1.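

At this position in this assay, an aromatic ring of carbon only is not required: (1H-pyrazol-1-yl)methyl in place of 4-isopropylphenyl is accepted at a modest cost (a 3.2-fold higher number from compound 2 to compound 3 (0.51 log units; beyond the scatter)). Ring type, chain and hydrogen-bond acceptors all change together, so this single pair cannot assign the step to any one of them. No measurement at hand accounts for the step.

Still open, from the compounds shown here alone, is whether 2-phenylethyl, pairing the chain of compound 3 with a carbon-only ring, restores the number of compound 2. Also open, going by these compounds, is whether a terminal amine or carboxylic acid on that chain is accepted.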